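The source may hold more compounds than are shown below. What is called first, only, known or untested is meant among the compounds shown, and "the series" means these compounds.

Measured in a functional assay on L6 cells (Rattus norvegicus) for inhibition; on this read-out higher numbers stand for weaker inhibition and lower numbers for stronger inhibition:
- Compound 1 `CC(C)c1c(C(=O)N(C)Cc2ccccc2)nn(-c2ccc(F)cc2)c1CC[C@@H](O)C[C@@H](O)CC(=O)O`: 2870 nM
- Compound 2 `CC(C)c1c(C(=O)N(C)Cc2ccccc2)nn(-c2ccc(F)cc2)c1OC[C@@H](O)C[C@@H](O)CC(=O)O`: 6720 nM
- Compound 3 `CC(C)c1c(C(=O)NCC2CCCCC2)nn(-c2ccc(F)cc2)c1OC[C@@H](O)C[C@@H](O)CC(=O)O`: "not determined" (no result reported)

Compound 3 has no number in this assay, so the step to compound 4 `Cc1ccc(CNC(=O)c2nn(-c3ccc(F)cc3)c(OC[C@@H](O)C[C@@H](O)CC(=O)O)c2C(C)C)cc1` has no measured start. The change is 4-methylphenyl in place of cyclohexyl on a saturated chain carbon bound to an amide-type nitrogen. Within the data shown here, the only measured step is a 2.3-fold higher number from compound 1 to compound 2 (0.37 log units; beyond the scatter) and it is modest, but it concerns the carboxy-dihydroxy chain, not this substituent. No size or direction of step can therefore be expected, and the estimate leans on compound 2 at 6720 nM, which carries the same chain. For compound 4 the expected value is about 5000 nM, with an estimated range of 1500 nM to 17000 nM, which is wide.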

Compound 4, half-maximal inhibitory concentration: 2110 nM
Compound 4: middle estimate off by 2.4-fold (0.37 log units), on the high side; the measured number falls inside the stated range.
By their numbers in this assay, from the lowest: compounds 4 and 1 (each within the scatter of the next); then compound 2.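

In this assay, the amide substituent on the carbonyl carbon proves able to shift the number on its own, with a 3.2-fold lower number from compound 2 to compound 4 (0.50 log units; beyond the scatter), towards stronger inhibition. Among these compounds, the earlier measured step concerned only the carboxy-dihydroxy chain, so this is the first measured change at this position. Nothing measured here offers an explanation for the shift.

The step from compound 3 to compound 4 cannot be read, so cyclohexylmethyl and 4-methylbenzyl remain uncompared. Going by these compounds, it also stays open how a plain benzylamino group or a (4-chlorobenzyl)amino group would behave on this carbonyl carbon.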